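Three Hydroxyphenyl Groups on One Shared Core

A few compounds are considered here, and "the series" means these few. Any claim that something is new, unique, unknown or untested is made for them only; others in the source may bear on it.

Measured so far:
compound 1, `Oc1ccc(-c2cc(-c3ccccc3O)cc(-c3cccc(O)c3)n2)cc1`, 0%
compound 2, `Oc1ccc(-c2cc(-c3ccccc3O)cc(-c3ccc(O)cc3)n2)cc1`, 0.4%
compound 3, `Oc1ccc(-c2cc(-c3cccc(O)c3)nc(-c3ccccc3O)c2)cc1`, 1.5%

All three were tested in an assay on isolated protein for inhibition of DNA topoisomerase 1 (Homo sapiens), with a stated time of 30 min, tested at 100 uM; a higher number here means more inhibition at the concentration tested (going by the name of the read-out), a lower number less inhibition. Compound 1 gives 0%, compound 2 gives 0.4% and compound 3 gives 1.5%; none of the three shows appreciable inhibition, and the differences among them lie within the scatter of the assay.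

Compound 2 differs from compound 1 by 4-hydroxyphenyl in place of 3-hydroxyphenyl on an aromatic carbon. This change gave a number 0.4 percentage points higher from compound 1 to compound 2 (within the scatter), so it left the read-out essentially unchanged. The difference between the core of compound 1 and the core of compound 3 is not broken down here.

Compound 4, `Oc1ccc(-c2cc(-c3ccc(O)cc3)nc(-c3ccccc3O)c2)cc1`, has not yet been measured in this assay. It differs from compound 3 by 4-hydroxyphenyl in place of 3-hydroxyphenyl on an aromatic carbon, the same kind of change as from compound 1 to compound 2, at a place described in the same words. Because the earlier step was a number 0.4 percentage points higher from compound 1 to compound 2 (within the scatter) and compound 3 gives 1.5%, compound 4 is expected to show a step of a number 0.5 percentage points higher from compound 3 to compound 4 (within the scatter) in this assay. Compound 4 is therefore estimated at 2%, in a range from 0% to 8%.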

Compound 4, a percentage reported as inhibition, at one concentration (the size of the read-out at that concentration, not a potency): 0%
Compound 4: the middle estimate sits 2 percentage points above what was measured; the range from low to high includes it.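

In this assay, putting 4-hydroxyphenyl in place of 3-hydroxyphenyl on the second core gave a number 1.5 percentage points lower from compound 3 to compound 4 (within the scatter). Set beside the earlier step, the change reads the same on both cores: the same change on two cores in this assay, a number 0.4 percentage points higher (within the scatter) from compound 1 to compound 2 and a number 1.5 percentage points lower (within the scatter) from compound 3 to compound 4, 1.9 percentage points apart, within the scatter of two such steps. This shows that the change left the read-out essentially unchanged on these two cores, but none of the four compounds shows appreciable inhibition, so the agreement is between steps taken near the floor of the read-out and does not show that the change would carry over to a core with appreciable inhibition.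

All the compounds shown carry only hydroxyphenyl groups on the shared core, which leaves open whether any other substituent would give measurable inhibition in this assay. An amine or a carboxylic acid in place of a hydroxyl group, or a longer chain between the core and the ring, would be among the changes still to be seen.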